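Shortening the ether chain on the dioxide core

The source may hold more compounds than are shown below. What is called first, only, known or untested is meant among the compounds shown, and "the series" means these compounds.

Measured so far:
compound 1, `[O-][n+]1nc(NCOCc2ccc(Cl)cc2)[n+]([O-])c2ccccc21`, 5100 nM in a functional assay on PC-3 cells (Homo sapiens) for cytotoxicity, read by MTT assay, with a stated time of 72 h; a lower number here means a stronger inhibitor, a higher number a weaker inhibitor
compound 2, `COc1ccc(COCNc2n[n+]([O-])c3ccccc3[n+]2[O-])cc1`, 52800 nM in this assay
compound 3, `CCCCOCNc1n[n+]([O-])c2ccccc2[n+]1[O-]`, 6010 nM in this assay

Compound 3 stands second highest of the three numbers. Its nearest neighbour is compound 1, with a 1.2-fold higher number from compound 1 to compound 3 (0.07 log units; within the scatter), a difference within the scatter; furthest is compound 2, with an 8.8-fold lower number from compound 2 to compound 3 (0.94 log units; beyond the scatter).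

Compound 4, `COCNc1n[n+]([O-])c2ccccc2[n+]1[O-]`, is not yet measured. It differs from compound 3 by hydrogen in place of propyl on a saturated chain carbon bound to an oxygen on a saturated carbon. Of the measured steps, only those that touch the same saturated chain carbon bear on it: a 1.2-fold higher number from compound 1 to compound 3 (0.07 log units; within the scatter) and an 8.8-fold lower number from compound 2 to compound 3 (0.94 log units; beyond the scatter). Both replace a ring at that position with propyl; neither removes carbon from the chain. The first shows that the nature of the group there can leave the number unchanged, the second that it can move the number substantially. Among the measured compounds shown here, no measured step trims the chain itself, so the direction is not fixed by the data.

The step of a 1.5-fold higher number from compound 3 to compound 4 (0.18 log units; within the scatter) is expected to fall near the scatter, leaning toward a higher number. Compound 4 is estimated at 9000 nM, within 3000 nM to 30000 nM.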

Compound 4, half-maximal inhibitory concentration: 4270 nM
The estimate for compound 4 lay 2.1-fold (0.32 log units) above the measured number, within the range that was stated.
By their numbers in this assay, from the lowest: compounds 4, 1 and 3 (each within the scatter of the next); then compound 2.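

In this assay, among the compounds shown here, this is the first step that shortens the chain itself, taking butoxy to methoxy, and it stays within the scatter (a 1.4-fold lower number from compound 3 to compound 4 (0.15 log units; within the scatter)). Hydrogen on the saturated chain carbon also reads level with 4-chlorophenyl at that place (a 1.2-fold lower number from compound 1 to compound 4 (0.08 log units; within the scatter)), so compound 1, compound 3 and compound 4 form one group of numbers despite carrying hydrogen, propyl or 4-chlorophenyl there. Compound 2 is the one compound that goes against this flat picture (a 12-fold lower number from compound 2 to compound 4 (1.09 log units; beyond the scatter)), which places the high number with its 4-methoxyphenyl group and shows that neither the chain length nor the mere presence of a ring sets the number among these four compounds.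

No measurement at hand gives a reason for the level group or for the gap to compound 2.

Going by these compounds, whether the flat response would survive an amine or a carboxylic acid at the end of the chain, or a much longer chain such as octyl, remains open. Also open, on these data alone, is whether the gap belongs to methoxy alone or would recur with a hydroxy or a fluoro group on the same ring.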